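Benzoxazole sulfonamides against HSP60/HSP10: notes on compound 4

The source may hold more compounds than are shown below. What is called first, only, known or untested is meant among the compounds shown, and "the series" means these compounds.

Measured so far:
compound 1, `O=S(=O)(Nc1ccc(-c2nc3cc(NS(=O)(=O)c4ccccc4)ccc3o2)cc1)c1ccccc1` — 80000 nM
compound 2, `C=Cc1ccc(S(=O)(=O)Nc2ccc3oc(-c4ccccc4)nc3c2)cc1` — > 100000 nM
compound 3, `O=S(=O)(Nc1ccc(-c2nc3ccccc3o2)cc1)c1cccc(O)c1` — 62000 nM

In an assay on cells for inhibition of HSP60/HSP10 (Homo sapiens), with a stated time of 60 min (on this read-out higher numbers stand for weaker inhibition and lower numbers for stronger inhibition), compound 3 gives 62000 nM, the lower of the two numbers available, yet its gap to compound 1 at 80000 nM lies within the scatter, so no order between compound 3 and compound 1 can be read from this assay. Compound 2 gives > 100000 nM in this assay, which is a limit of the assay and not a number. That value is the limit of > 100000 nM in this assay, at which 1 of the 3 values shown sits.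

Compound 4, `C=Cc1ccc(S(=O)(=O)Nc2ccc(-c3nc4ccccc4o3)cc2)cc1`, is the next compound to be measured in this assay. It is reached from compound 3 by 4-vinylphenyl in place of 3-hydroxyphenyl on a sulfonyl sulfur. For the measured compounds named here, no step between measured compounds with this change is available, so the direction has to be set from the numbers alone; compound 2, which also carries a 4-vinylphenyl on a sulfonyl sulfur, sits at the limit, while the shared core with the 3-hydroxyphenyl in compound 3 gives the lower number of the set.

The expectation is therefore a step from compound 3 to compound 4 of a 1.5-fold higher number from compound 3 to compound 4 (0.16 log units; within the scatter) in this assay, towards weaker inhibition, with a fair chance that only a limit is reported. Compound 4 is estimated at 90000 nM in this assay, expected to fall between 40000 nM and 250000 nM.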

Compound 4, half-maximal inhibitory concentration: > 100000 nM
Compound 4 gave a limit, no number; the forecaster's own chance of this, stated with the estimate: 45%; middle value at least 1.1-fold (0.04 log units) from the limit.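

For the compounds shown here, with the shared core held constant, 4-vinylphenyl in place of 3-hydroxyphenyl on a sulfonyl sulfur gives the first direct reading at this position in this assay: an at least 1.6-fold higher number from compound 3 to compound 4 (0.20 log units; that floor lies within the scatter). This step is only a floor, set by a limit of the assay and not by a number, so it fixes no order between the two compounds and leaves the true size of the step unknown. Compound 4 now stands with compound 2, the other compound carrying 4-vinylphenyl on a sulfonyl sulfur, and each gives a limit rather than a number: the limit of > 100000 nM in this assay, at which 2 of the 4 values shown sit.

The change removes the hydroxyl and brings in the vinyl group at once, and the compounds shown leave open which of the two carries the step, or whether either does. Also open, on these data alone, is how an amine or a carboxylic acid on the phenyl attached to the sulfonyl sulfur would read in this assay, and whether any such group would give a number clearly separated from the values seen so far.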